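The compounds below may be only part of what the source reports. "The series", "measured", "known", "first", "only" and "open" are said of these compounds alone.

The measured compounds in a functional assay (Nicotiana tabacum); on this read-out higher numbers stand for weaker inhibition and lower numbers for stronger inhibition:

compound 1, `CCCNc1nc(SC)nc2ncccc12`, gives 270 nM;
compound 2, `CCC(C)Nc1nc(SC)nc2ncccc12`, gives 860 nM;
compound 3, `COCCNc1nc(SC)nc2ncccc12`, gives 2530 nM.

Compound 4, `CCOCCNc1nc(SC)nc2ncccc12`, is not yet measured. It differs from compound 3 by methyl in place of hydrogen on a saturated chain carbon bound to an oxygen on a saturated carbon. The same kind of change has been made once before, from compound 1 to compound 2: methyl in place of hydrogen on a saturated chain carbon bound to a nitrogen on an aromatic ring and a saturated chain carbon, which gave a 3.2-fold higher number from compound 1 to compound 2 (0.50 log units; beyond the scatter). The two places are not the same: in the earlier case the carbon is bound to a nitrogen on an aromatic ring and a saturated chain carbon, here it is bound to an oxygen on a saturated carbon. The cores of compound 1 and compound 3 differ by methoxy in place of methyl on a saturated chain carbon, two bonds along the chain from a nitrogen on an aromatic ring, a change that gave a 9.4-fold higher number from compound 1 to compound 3 (0.97 log units; beyond the scatter). Because the earlier step of a 3.2-fold higher number from compound 1 to compound 2 (0.50 log units; beyond the scatter) was modest and the place differs, a smaller step is expected here, a 1.8-fold higher number from compound 3 to compound 4 (0.25 log units; within the scatter). Compound 4 is thus expected to give 4500 nM in this assay, between 1800 nM and 12000 nM.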

Compound 4, half-maximal inhibitory concentration: 7590 nM
Compound 4: middle estimate off by 1.7-fold (0.23 log units), on the low side, within the range that was stated.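

Measured in this assay, the series now shows a 3.0-fold higher number from compound 3 to compound 4 (0.48 log units; beyond the scatter) together with an 8.8-fold higher number from compound 2 to compound 4 (0.95 log units; beyond the scatter) and a 28-fold higher number from compound 1 to compound 4 (1.45 log units; beyond the scatter). Methyl in place of hydrogen raised the number by about the same amount at two different places on the chain: the same change on two cores in this assay, a 3.2-fold higher number (0.50 log units; beyond the scatter) from compound 1 to compound 2 and a 3.0-fold higher number (0.48 log units; beyond the scatter) from compound 3 to compound 4, 1.1-fold (0.03 log units) apart, within the scatter of two such steps. This single pair of steps shows that the change carried over between these two cores, but not that it would do so on any other core, nor why the two steps agree.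

The compounds shown leave open whether a longer chain, such as propoxy in place of the ethoxy, would raise the number further. From the compounds shown here alone, how an amine or a carboxylic acid in that place would read also remains open.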